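This account rests on a few compounds, and the source may have more. Where it says the series, first, only, none or still open, it means among the compounds named here.

Compound 2 `O=C(Nc1ccccc1Br)N[C@@H]1CCN(c2ccccn2)C1` is the unsubstituted member of the set, and in a functional assay for antagonist activity at transient receptor potential cation channel subfamily V member 1 (Rattus norvegicus), read by FLIPR (a lower number here means a less potent compound, a higher number a more potent compound, by a factor of ten per unit of this negative logarithm), compound 2 gives only a limit, < 6.6, so its true value is not pinned down. Compound 1 `O=C(Nc1ccccc1Br)N[C@@H]1CCN(c2cccc(C(F)(F)F)n2)C1` gives 7.2 in this assay, and compound 3 `O=C(Nc1ccccc1Br)N[C@@H]1CCN(c2cc(C(F)(F)F)ccn2)C1` gives 6.9. Both measured steps that touch compound 2 go through that limit of < 6.6 in this assay, at which 1 of the 3 values shown sits: the step of a number at least 0.60 log units lower from compound 1 to compound 2 (beyond the scatter) removes trifluoromethyl, and the step of a number at least 0.30 log units higher from compound 2 to compound 3 (that floor lies within the scatter) puts trifluoromethyl back at a different aromatic carbon. Compound 4 `Cc1ccc(N2CC[C@@H](NC(=O)Nc3ccccc3Br)C2)nc1` differs from compound 2 by methyl in place of hydrogen on an aromatic carbon. Among the measured compounds shown here, no measured step places methyl at this carbon, and the only comparable additions on the same ring are of trifluoromethyl, not methyl, so the weight of those steps is uncertain here. Still, both measured additions of a group to the ring of compound 2 moved the readout upward, one of them beyond the scatter, and a similar direction is expected for methyl, with a step of a number at least 0.20 log units higher from compound 2 to compound 4 (that floor lies within the scatter) that is modest at best. Compound 4 is therefore estimated at 6.8, with a range from 6.3 to 7.3 in this assay.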

Compound 4, negative logarithm of the antagonist equilibrium constant: < 6.7
Compound 4 ended at the assay's limit; the forecaster's own chance of this, stated with the estimate: 30%; middle value at least 0.10 log units from the limit.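

In this assay compound 4 gives < 6.7 as a limit. Compound 2 gives < 6.6 as a limit too, so the step between compound 2 and compound 4 cannot be read. The compounds shown leave open whether methyl in place of hydrogen at this carbon changes the potency at all.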